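Moving the Chlorine Along the Amide Side Chain

The source may report more compounds than this note shows. Statements on the series, on what has been measured and on what is new or still open speak of the compounds shown alone.

Measured so far:
compound 1 `CCOC(=O)c1c(O)c2cccnc2n(-c2ccccc2)c1=O` — in a functional assay on the whole organism for inhibition, with Rattus norvegicus as the target, read by paw edema, at a dose of 100 mg/kg by the oral route (on this read-out higher numbers stand for more inhibition at the one dose given (going by the name of the read-out) and lower numbers for less inhibition), compound 1 gives 23.5%
compound 2 `CN(C)CCNC(=O)c1c(O)c2cccnc2n(-c2ccccc2)c1=O` — in this assay compound 2 gives 22.6%
compound 3 `O=C(Nc1ccc(Cl)cc1)c1c(O)c2cccnc2n(-c2ccccc2)c1=O` — in this assay compound 3 gives 11.6%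

All three share one core and differ only in the group on the carbonyl carbon. Compound 3 stands lowest of the three numbers: the change a number 11.9 percentage points lower from compound 1 to compound 3 (beyond the scatter) and the change a number 11 percentage points lower from compound 2 to compound 3 (beyond the scatter) are both beyond the scatter, while a number 0.9 percentage points lower from compound 1 to compound 2 (within the scatter) is not. So the (4-chlorophenyl)amino variant sits modestly under both the ethoxy and the aminoalkyl amide.

Compound 4 `O=C(Nc1cccc(Cl)c1)c1c(O)c2cccnc2n(-c2ccccc2)c1=O` is the unmeasured partner of compound 3. The difference is 3-chlorophenyl in place of 4-chlorophenyl on an amide-type nitrogen. For the measured compounds named here, none of the measured steps moves a chlorine from one position of the ring to another; the only steps available exchange whole side chains, and they bracket compound 3 as the weak end. With the same atoms merely rearranged, compound 4 is expected to give roughly what compound 3 gives, a step of a number 2.4 percentage points higher from compound 3 to compound 4 (within the scatter) not beyond the scatter. The estimate for compound 4 in this assay is 14%, within 2% to 28%.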

Compound 4, a percentage reported as inhibition, in the whole organism at one dose (the size of the read-out at that dose, not a potency): 7.6%
Beside the measured number, compound 4's estimate is 6.4 percentage points above it, and the stated range covers the measured number.
By their numbers in this assay, from the lowest: compounds 4 and 3 (each within the scatter of the next); then compounds 2 and 1 (each within the scatter of the next).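

In this assay, exchanging 4-chlorophenyl for 3-chlorophenyl on the amide-type nitrogen gives a number 4 percentage points lower from compound 3 to compound 4 (within the scatter), so this shift of the chlorine produces no clear change in the read-out. The earlier steps shown here exchanged whole side chains, whereas this pair shows that the low result is not confined to the 4-chlorophenyl amide: the 3-chlorophenyl amide also falls short, with a number 15 percentage points lower from compound 2 to compound 4 (beyond the scatter) and a number 15.9 percentage points lower from compound 1 to compound 4 (beyond the scatter). No supporting measurement is available to explain these numbers.

The compounds shown leave open how a plain phenyl or a 4-methoxyphenyl group on the amide-type nitrogen would read. They also leave open what a free carboxylic acid would give in place of the ethoxy group on the carbonyl carbon.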